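Three Limits and a Fourth Compound Awaiting Measurement

The compounds below may be only part of what the source reports. "The series", "measured", "known", "first", "only" and "open" are said of these compounds alone.

Compound 1 `CC1=CCC[C@](C)(CC/C(C)=C/CC2=C(O)C(=O)C=C(N[C@@H](C(=O)O)C(C)C)C2=O)[C@@H]1C`: in an ADME assay on KB cells (Homo sapiens) for cytotoxicity, with a stated time of 48 h (on this read-out higher numbers stand for weaker inhibition and lower numbers for stronger inhibition), compound 1 gives > 10 ug/mL, a limit of the assay.
Compound 2 `CC1=CCC[C@](C)(CC/C(C)=C/CC2=C(O)C(=O)C=C(N[C@H](CO)C(=O)O)C2=O)[C@@H]1C`: in this assay compound 2 gives > 10 ug/mL, also a limit.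
Compound 3 `C=C1[C@H](C)CCC[C@]1(C)CC/C(C)=C/CC1=C(O)C(=O)C=C(N[C@@H](CO)C(=O)O)C1=O`: in this assay compound 3 gives > 10 ug/mL, again a limit.

Compound 2 and compound 1 share a core and differ by isopropyl in place of hydroxymethyl on a saturated chain carbon bound to an amine nitrogen and a carbonyl carbon. The step that the two limits leave unreadable from compound 2 to compound 1 cannot be sized, since both values are limits; this is the one fact bearing on the change, (the limit of > 10 ug/mL in this assay, at which 3 of the 3 values shown sit). The unmeasured compound 4 `C=C1[C@H](C)CCC[C@]1(C)CC/C(C)=C/CC1=C(O)C(=O)C=C(N[C@H](C(=O)O)C(C)C)C1=O` differs from compound 3 by isopropyl in place of hydroxymethyl on a saturated chain carbon bound to an amine nitrogen and a carbonyl carbon, the same change on a different core; the difference between the two cores is not broken down here.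

Because every measured value sits at the limit of > 10 ug/mL in this assay, at which 3 of the 3 values shown sit, compound 4 is expected to behave alike, and the step that the limit leaves unreadable from compound 3 to compound 4 is estimated to be small. Compound 4 is expected to give about 15 ug/mL, most likely reported only as a limit, within a range from 5 ug/mL to 50 ug/mL.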

Compound 4, half-maximal inhibitory concentration: > 10 ug/mL
Compound 4 was reported as a limit (the forecaster's own chance of this, stated with the estimate: 85%); the middle value lies beyond the limit too.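

No size can be given for the step between compound 3 and compound 4, whose results are both limits. The compounds shown leave open how strongly any of them inhibits in this assay, and whether isopropyl in place of hydroxymethyl changes that at all.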